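Chloro in Place of Fluoro: Expectation for Compound 4

This account rests on a few compounds, and the source may have more. Where it says the series, first, only, none or still open, it means among the compounds named here.

Measured in an assay for binding affinity to protein lin-28 homolog A (Mus musculus), with a stated time of 1 h; on this read-out higher numbers stand for weaker inhibition and lower numbers for stronger inhibition:
compound 1 `O=S(=O)(Nc1ccccc1NS(=O)(=O)c1ccccc1)c1ccccc1` gives 32200 nM;
compound 2 `O=S(=O)(Nc1ccccc1NS(=O)(=O)c1ccc(F)cc1)c1ccccc1` gives 13900 nM;
compound 3 `O=S(=O)(Nc1ccccc1NS(=O)(=O)c1ccc(F)cc1)c1ccc(F)cc1` gives 28300 nM.

Compound 3 holds the second highest of the three numbers. Compound 1 lies within the scatter of it, while the step of a 2.0-fold higher number from compound 2 to compound 3 (0.31 log units; beyond the scatter) is beyond the scatter. Compound 4 `O=S(=O)(Nc1ccccc1NS(=O)(=O)c1ccc(Cl)cc1)c1ccc(F)cc1` differs from compound 3 by chloro in place of fluoro on an aromatic carbon. No measured step puts chloro in place of fluoro; the two shown, a 2.3-fold lower number from compound 1 to compound 2 (0.36 log units; beyond the scatter) and a 2.0-fold higher number from compound 2 to compound 3 (0.31 log units; beyond the scatter), both put fluoro in place of hydrogen and are modest and opposite in sign. A change of this kind on the shared core is therefore expected to move this assay only modestly, if at all, so the step of a 1.3-fold lower number from compound 3 to compound 4 (0.11 log units; within the scatter) is estimated. Compound 4 is expected to give 22000 nM, between 9000 nM and 55000 nM.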

Compound 4, half-maximal inhibitory concentration: 27300 nM
Compound 4: middle estimate off by 1.2-fold (0.09 log units), on the low side, within the range that was stated.
By their numbers in this assay, from the lowest: compounds 2, 4, 3 and 1 (each within the scatter of the next, the first and the last beyond it).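

In this assay, this position was first tested with a halogen other than fluoro, and the exchange of fluoro for chloro gives a 1.0-fold lower number from compound 3 to compound 4 (0.02 log units; within the scatter), so the two groups cannot be told apart here. Chloro in place of hydrogen gives a 2.0-fold higher number from compound 2 to compound 4 (0.29 log units; within the scatter), which lies within the scatter, whereas fluoro in place of hydrogen gives a 2.0-fold higher number from compound 2 to compound 3 (0.31 log units; beyond the scatter), which lies beyond it. Nothing available explains these readings.

The compounds shown leave open whether an amine or a carboxylic acid at this position would read differently from the halogens.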